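Swapping Chloro for Bromo: Measured and Expected Potency

The source may hold more compounds than are shown below. What is called first, only, known or untested is meant among the compounds shown, and "the series" means these compounds.

The measured compounds and their values in a functional assay on A549 cells (Homo sapiens) for inhibition, read by MTT assay, with a stated time of 48 h; a lower number here means a stronger inhibitor, a higher number a weaker inhibitor:

compound 1, `O=[N+]([O-])c1ccc2[nH]cc(C(c3ccc(Cl)cc3)c3c[nH]c4ccc([N+](=O)[O-])cc34)c2c1`, gives > 100000 nM, which is a limit of the assay and not a number.
compound 2, `O=[N+]([O-])c1ccc2[nH]cc(C(c3ccc(Br)cc3)c3c[nH]c4ccc([N+](=O)[O-])cc34)c2c1`, gives > 100000 nM, again a limit of the assay rather than a number.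
compound 3, `OC[C@H]1O[C@@H](n2cc(C(c3ccc(Cl)cc3)c3cn([C@@H]4O[C@H](CO)[C@@H](O)[C@H](O)[C@H]4O)c4ccc(Br)cc34)c3cc(Br)ccc32)[C@H](O)[C@@H](O)[C@@H]1O`, gives 2700 nM.

Compound 1 and compound 2 share one core and differ only in bromo in place of chloro on an aromatic carbon. The size of the step that the two limits leave unreadable from compound 1 to compound 2 cannot be read, since both values sit at the limit of > 100000 nM in this assay, at which 2 of the 3 values shown sit. Compound 3 is built on a different core; the difference between the two cores is not broken down here, and compound 3 is the only one of the three to give an actual number.

Compound 4, `OC[C@H]1O[C@@H](n2cc(C(c3ccc(Br)cc3)c3cn([C@@H]4O[C@H](CO)[C@@H](O)[C@H](O)[C@H]4O)c4ccc(Br)cc34)c3cc(Br)ccc32)[C@H](O)[C@@H](O)[C@@H]1O`, has not yet been measured. Among the measured compounds shown here, it differs from compound 3 by bromo in place of chloro on an aromatic carbon, the same change as the one between compound 1 and compound 2, at the same place on the ring. That earlier instance gives no usable size, so the expectation for compound 4 rests on the nature of the change alone: one halogen gives way to another of the same heavy-atom count, with no change in hydrogen-bond donors, acceptors or charge. Such a change is expected to move the value little, and the step of a 1.1-fold lower number from compound 3 to compound 4 (0.03 log units; within the scatter) is expected to fall within the usual scatter of this assay. Compound 4 is therefore estimated at about 2500 nM in this assay, with a likely range from 1000 nM to 7000 nM.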

Compound 4, half-maximal inhibitory concentration: 2500 nM
Compound 4: middle estimate and measured number agree at the digits printed; measured number inside the range.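

In this assay, bromo in place of chloro on the core of compound 3 gives a 1.1-fold lower number from compound 3 to compound 4 (0.03 log units; within the scatter), so on this core the 4-chlorophenyl and 4-bromophenyl versions cannot be told apart. On the core of compound 1 the same change cannot be read, since compound 1 and compound 2 each give a limit of the assay and not a number: the limit of > 100000 nM in this assay, at which 2 of the 4 values shown sit. This leaves a single readable instance of the change, so the result says nothing about whether the two cores respond to it in the same way, and it cannot be taken as a rule that holds from one core to the other.

At this place on the ring, the compounds shown carry only chloro or bromo, so it remains open whether a different group there, such as an amine, a carboxylic acid or a longer chain, would shift the value on the core of compound 3 by more than the scatter. It also remains open which part of the core of compound 3 sets it apart from the core of compound 1, as these cores differ in more than one place and no compound shown separates those differences.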